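The source may hold more compounds than are shown below. What is called first, only, known or untested is meant among the compounds shown, and "the series" means these compounds.

Series notes. Compound 1 `NNc1nc2ccc([N+](=O)[O-])cc2s1` in an ADME assay on MT4 cells (Homo sapiens) for cytotoxicity, read by MTT assay, with a stated time of 5 days (a higher number here means that more compound is tolerated, a lower number that less compound is tolerated), gives 12.8 ug/mL, while compound 2 `Cc1ccc2nc(NN)sc2c1` in this assay gives 4.52 ug/mL. The change between them is methyl in place of nitro on an aromatic carbon and the step it made is a 2.8-fold lower number from compound 1 to compound 2 (0.45 log units; beyond the scatter). Compound 3 `O=[N+]([O-])c1ccc(-c2nnc(-c3cccnc3)n2Nc2nc3ccc([N+](=O)[O-])cc3s2)cc1` in this assay gives 50.8 ug/mL, the highest of the three numbers; the difference between the core of compound 3 and the core of compound 1 is not broken down here. Compound 4 `Cc1ccc2nc(Nn3c(-c4ccc([N+](=O)[O-])cc4)nnc3-c3cccnc3)sc2c1` has not been measured in this assay. It differs from compound 3 by methyl in place of nitro on an aromatic carbon, the same change made from compound 1 to compound 2, at the same place. Among the measured compounds shown here, for compound 4 a step of a 2.8-fold lower number from compound 3 to compound 4 (0.45 log units; beyond the scatter) in this assay is expected, resting on the step of a 2.8-fold lower number from compound 1 to compound 2 (0.45 log units; beyond the scatter) seen for the one earlier example of this change. The estimate for compound 4 in this assay is 18 ug/mL, expected to fall between 8 ug/mL and 40 ug/mL.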

Compound 4, half-maximal cytotoxic concentration: 64.4 ug/mL
Compound 4: the middle estimate sits 3.6-fold (0.55 log units) below what was measured, and the stated range ends below it.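

In this assay, among the compounds shown here, methyl in place of nitro on an aromatic carbon gives a 1.3-fold higher number from compound 3 to compound 4 (0.10 log units; within the scatter), so on this core the change produces no step distinct from scatter. Set beside the earlier step, the change does not carry over from the core of compound 1 to the core of compound 3 with one size: the same change on two cores in this assay, a 2.8-fold lower number (0.45 log units; beyond the scatter) from compound 1 to compound 2 and a 1.3-fold higher number (0.10 log units; within the scatter) from compound 3 to compound 4, 3.6-fold (0.56 log units) apart, beyond the scatter of two such steps

This rests on a single pair per core, and it shows neither why the two cores differ nor what the change would do on a further core. Open, as far as these compounds go, is whether a chloro group or a carboxylic acid at this aromatic carbon would follow the pattern of the core of compound 1 or that of the core of compound 3.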